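Replacing the 2,4-dichlorophenyl group of compound 3

The compounds below may be only part of what the source reports. "The series", "measured", "known", "first", "only" and "open" are said of these compounds alone.

Results so far in a functional assay on HT-1080 cells (Homo sapiens) for cytotoxicity, read by MTT assay, with a stated time of 72 h; a lower number here means a stronger inhibitor, a higher number a weaker inhibitor:
- Compound 1 `COc1ccc(/C=C2\CCC/C(=C\c3cccc(Cl)c3)C2=O)cc1OC` gives 4900 nM
- Compound 2 `COc1cccc(/C=C2\CCC/C(=C\c3ccc(OC)c(OC)c3)C2=O)c1` gives 4600 nM
- Compound 3 `COc1ccc(/C=C2\CCC/C(=C\c3ccc(Cl)cc3Cl)C2=O)cc1OC` gives 10500 nM

Compound 3 has the highest number of the three, which makes it the weakest inhibitor so far. Two modest steps show this: there is a 2.1-fold higher number from compound 1 to compound 3 (0.33 log units; beyond the scatter), and there is a 2.3-fold higher number from compound 2 to compound 3 (0.36 log units; beyond the scatter). Both steps bring in the 2,4-dichlorophenyl group. The remaining pair barely separates, with a 1.1-fold lower number from compound 1 to compound 2 (0.03 log units; within the scatter).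

Compound 4 `COc1ccc(/C=C2\CCC/C(=C\c3ccc(O)c(Cl)c3)C2=O)cc1OC` has not yet been measured. It differs from compound 3 in one group: 3-chloro-4-hydroxyphenyl in place of 2,4-dichlorophenyl on a double-bonded chain carbon bound to a double-bonded ring carbon. The 3-chloro-4-hydroxyphenyl group takes the place of the 2,4-dichlorophenyl group on a double-bonded chain carbon bound to a double-bonded ring carbon.

Within the data shown here, no measured step shows what a hydroxy group does, so the guide is only partial. Read backwards, a 2.1-fold higher number from compound 1 to compound 3 (0.33 log units; beyond the scatter) and a 2.3-fold higher number from compound 2 to compound 3 (0.36 log units; beyond the scatter) suggest that losing the 2,4-dichlorophenyl group may lower the number modestly. A modest drop, not a large one, is therefore expected in this assay. The expected change is a 2.6-fold lower number from compound 3 to compound 4 (0.42 log units; beyond the scatter). Compound 4 is estimated at 4000 nM, with an expected range of 1300 nM to 10000 nM.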

Compound 4, half-maximal inhibitory concentration: 7600 nM
Compound 4: middle estimate off by 1.9-fold (0.28 log units), on the low side, within the range that was stated.
By their numbers in this assay, from the lowest: compounds 2, 1, 4 and 3 (each within the scatter of the next, the first and the last beyond it).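

In this assay, among these compounds, this is the first look at a hydroxy group on the aromatic ring at this place, on a double-bonded chain carbon bound to a double-bonded ring carbon, and adding it to the 3-chlorophenyl group gives a 1.6-fold higher number from compound 1 to compound 4 (0.19 log units; within the scatter). So the 1 hydrogen-bond donor of the 3-chloro-4-hydroxyphenyl group, which no earlier compound carries here, produces no change that can be told from the scatter, and the same holds for the swap from the 2,4-dichlorophenyl group, with a 1.4-fold lower number from compound 3 to compound 4 (0.14 log units; within the scatter), and from the 3-methoxyphenyl group, with a 1.7-fold higher number from compound 2 to compound 4 (0.22 log units; within the scatter). Compound 4 therefore cannot be separated from any of the other three compounds, even though compound 3 is separated from compounds 1 and 2, and no measurement on hand offers an explanation for this.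

Going by these compounds, it remains open whether a hydroxyphenyl group carrying no chlorine would behave in the same way at this place. On these data alone, it is also open whether an amine or a carboxylic acid in place of the hydroxy group would give a step beyond the scatter.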